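Lengthening the Chain on Compound 3 Toward Compound 4

The compounds below may be only part of what the source reports. "The series", "measured", "known", "first", "only" and "open" are said of these compounds alone.

Three compounds share one core and differ only in the length of a saturated chain attached to it: compound 1 `CCCCCc1cc2cn([C@H]3C[C@H](O)[C@@H](CO)O3)c(=O)nc2o1`, compound 2 `CCCCCCCc1cc2cn([C@H]3C[C@H](O)[C@@H](CO)O3)c(=O)nc2o1` and compound 3 `CCCCCCCCc1cc2cn([C@H]3C[C@H](O)[C@@H](CO)O3)c(=O)nc2o1`. All three were tested in a functional assay on HEL cells (Homo sapiens) for cytotoxicity, read by microscopy; a higher number here means that more compound is tolerated, a lower number that less compound is tolerated. In this assay compound 1 gives > 50000 nM, which is a limit of the assay rather than a number. Compound 2 likewise gives only a limit, > 50000 nM. Compound 3 also stands at a limit, > 50000 nM, so where it truly sits is not known. Because every value sits at the limit of > 50000 nM in this assay, at which 3 of the 3 values shown sit, no step among these compounds can be read: a step that the two limits leave unreadable from compound 1 to compound 2, a step that the two limits leave unreadable from compound 1 to compound 3 and a step that the two limits leave unreadable from compound 2 to compound 3.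

The unmeasured compound 4 `CCCCCCCCCCc1cc2cn([C@H]3C[C@H](O)[C@@H](CO)O3)c(=O)nc2o1` continues the same series. The change is ethyl in place of hydrogen on a saturated chain carbon, eight bonds along the chain from an aromatic carbon. Going by the values given here, the only measured steps that bear on this change are the three unreadable ones just named, so they offer neither a size nor a direction, only the observation that every chain length so far was tolerated up to the limit. The step of a number no higher from compound 3 to compound 4 (the limit leaves the size open) is therefore expected to be none beyond the scatter. Compound 4 is estimated to give 50000 nM, somewhere within 25000 nM to 100000 nM, most likely reported once more as a limit.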

Compound 4, minimum cytotoxic concentration: > 50000 nM
Compound 4 gave a limit, no number; the forecaster's own chance of this, stated with the estimate: 85%; the middle value lies on the limit itself.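

In this assay compound 4 gives > 50000 nM as well, which is a limit and not a number. The steps from compound 1, compound 2 and compound 3 to compound 4 therefore cannot be read, because every value stands at the same limit: the limit of > 50000 nM in this assay, at which 4 of the 4 values shown sit. The compounds shown leave open how much of any of them the cells would tolerate, and whether chain length makes any difference to that.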